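The source may report more compounds than this note shows. Statements on the series, on what has been measured and on what is new or still open speak of the compounds shown alone.

Of the compounds shown here, three have been measured in a functional assay on Caco-2 cells (Homo sapiens) for antiproliferative activity, read by MTT assay, with a stated time of 24 h; on this read-out lower numbers stand for stronger inhibition and higher numbers for weaker inhibition. Compound 1 `COc1cc(C2CC(c3ccccc3)=NN2c2ccc(-c3ccccc3)nn2)cc(OC)c1OC` gives only a limit there, > 100000 nM. Compound 2 `COc1cc(C2CC(c3ccc(Cl)cc3)=NN2c2ccc(-c3ccccc3)nn2)cc(OC)c1OC` likewise gives only a limit, > 100000 nM. Compound 3 `COc1ccc(C2=NN(c3ccc(-c4ccccc4)nn3)C(c3ccc(C(F)(F)F)cc3)C2)cc1` gives 65000 nM.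

For the measured compounds named here, compound 3 thus stands as the only compound with a number in this assay; the other two values are limits, as the limit of > 100000 nM in this assay, at which 2 of the 3 values shown sit, records. The step from compound 1 to compound 2 is a step that the two limits leave unreadable from compound 1 to compound 2, so the chloro in place of hydrogen on an aromatic carbon leaves no readable size.

Compound 4 `COc1ccc(C2=NN(c3ccc(-c4ccccc4)nn3)C(c3cc(OC)c(OC)c(OC)c3)C2)cc1` differs from compound 3 by 3,4,5-trimethoxyphenyl in place of 4-(trifluoromethyl)phenyl on a saturated ring carbon. Going by the values given here, no measured step changes the group on the saturated ring carbon, so none bears directly on this change. Compound 1 carries the same 3,4,5-trimethoxyphenyl on its saturated ring carbon and gives only a limit in this assay, > 100000 nM. Compound 4 is therefore expected to sit near that limit. The expected step is a 1.5-fold higher number from compound 3 to compound 4 (0.19 log units; within the scatter), toward weaker inhibition or within the scatter. The estimate for compound 4 is 100000 nM, between 40000 nM and 300000 nM.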

Compound 4, half-maximal inhibitory concentration: > 100000 nM
Compound 4: only a limit was reported; the forecaster's own chance of this, stated with the estimate: 50%; the middle value lies on the limit itself.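

For the compounds shown here, replacing 4-(trifluoromethyl)phenyl with 3,4,5-trimethoxyphenyl on the saturated ring carbon gives the first step at this position in this assay, an at least 1.5-fold higher number from compound 3 to compound 4 (0.18 log units; that floor lies within the scatter); that floor does not lift the change beyond the scatter, and its true size stays open. The steps to compound 4 from compound 1 and from compound 2 cannot be read, as each joins two limits. Compound 4 therefore adds another limit and no second number, leaving compound 3 alone with a measured value: the limit of > 100000 nM in this assay, at which 3 of the 4 values shown sit.

The compounds shown leave open whether the 4-(trifluoromethyl)phenyl on the saturated ring carbon is what sets compound 3 apart from the limits. They also leave open how a phenyl group bearing an amine or a carboxylic acid would read in that place.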